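Chloro on the fused ring of compound 2

The source may report more compounds than this note shows. Statements on the series, on what has been measured and on what is new or still open speak of the compounds shown alone.

Three compounds share a sulfanylmethyl link between a heteroaromatic ring and a chromone-like core, and each has been examined in a functional assay on MCF7 cells (Homo sapiens) for cytotoxicity, read by MTT assay, with a stated time of 72 h; a lower number here means a stronger inhibitor, a higher number a weaker inhibitor. Compound 1 `O=c1cc(CSc2nc3ccccc3s2)oc2ccc(Cl)cc12` sits at the limit of this assay, giving > 25000 nM, which is a limit and not a number. Compound 2 `Cc1nnc(SCc2cc(=O)c3ccccc3o2)s1` likewise reaches only the limit of this assay, with > 25000 nM. Compound 3 `Nc1nnc(SCc2coc3ccccc3c2=O)s1` also gives a limit in this assay, > 25000 nM. Going by the values given here, compound 2 therefore stands where every value so far stands: at the limit of > 25000 nM in this assay, at which 3 of the 3 values shown sit, with no number to separate it from the others.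

Compound 4 `Cc1nnc(SCc2cc(=O)c3cc(Cl)ccc3o2)s1` differs from compound 2 by chloro in place of hydrogen on an aromatic carbon. Among the compounds with values here, no measured step between two numbered values exists to calibrate this change. Since compound 1, which already carries a chloro on the same kind of position, gives > 25000 nM, no step beyond the scatter is expected from compound 2 to compound 4, and the expected step is a step that the limit leaves unreadable from compound 2 to compound 4. Compound 4 is estimated at 30000 nM in this assay, within 12000 nM to 100000 nM, most likely reported again as a limit.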

Compound 4, half-maximal inhibitory concentration: > 25000 nM
Compound 4: no number, only a limit (the forecaster's own chance of this, stated with the estimate: 85%); the middle value lies beyond the limit too.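

No step can be read from compound 2 to compound 4 in this assay, since both give only a limit: the limit of > 25000 nM in this assay, at which 4 of the 4 values shown sit.

The compounds shown leave open what chloro in place of hydrogen on an aromatic carbon does, and which structure would give a number here.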